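From Methyl to Phenyl on a Shared Core

The source may report more compounds than this note shows. Statements on the series, on what has been measured and on what is new or still open speak of the compounds shown alone.

- Compound 1 `Cc1nnc(-c2nn(-c3ccccc3)c(-c3ccccc3)c2C#N)c2cn(-c3ccccc3)nc12` gives 92000 nM
- Compound 2 `N#Cc1c(-c2nnc(-c3nn(-c4ccccc4)c(-c4ccccc4)c3C#N)c3nn(-c4ccccc4)cc23)nn(-c2ccccc2)c1-c1ccccc1` gives 13300 nM

In a functional assay on IGROV-1 cells (Homo sapiens) for inhibition, read by sulforhodamine B assay, with a stated time of 48 h (on this read-out lower numbers stand for stronger inhibition of growth and higher numbers for weaker inhibition of growth), compound 1 has the higher of the two numbers, so it is the weaker of the pair, and the gap to compound 2 lies beyond the usual scatter. Compound 3 `N#Cc1c(-c2nnc(-c3ccccc3)c3nn(-c4ccccc4)cc23)nn(-c2ccccc2)c1-c1ccccc1` keeps the core of compound 1 but carries phenyl in place of methyl on an aromatic carbon of the six-membered aromatic ring with 2 nitrogen. Going by the values given here, no measured pair shows this swap on its own, so any forecast is loose. Among the compounds with values here, the only guide is that, on the same scale, compound 2 gives 13300 nM and compound 1 gives 92000 nM, which leaves compound 2 with the lower number. A moderate fall beyond the scatter is therefore expected in this assay, an estimated 3.1-fold lower number from compound 1 to compound 3 (0.49 log units; beyond the scatter) in all. For compound 3 the estimated value is 30000 nM, with an expected range from 9000 nM to 90000 nM at most likely.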

Compound 3, concentration for 50% growth inhibition: 94800 nM
Compound 3: the middle estimate sits 3.2-fold (0.50 log units) below what was measured; the whole stated range lies below it.
By their numbers in this assay, from the lowest: compound 2; then compounds 1 and 3 (each within the scatter of the next).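

In this assay, going by these compounds alone, phenyl in place of methyl on an aromatic carbon gives a 1.0-fold higher number from compound 1 to compound 3 (0.01 log units; within the scatter) and this is the first direct reading of a change at this position. Enlarging the group from a single carbon to a six-membered aromatic ring of carbon only therefore leaves growth inhibition in this assay unchanged within the usual scatter. The measurements shown offer no explanation for this result.

The compounds shown leave open whether a group of a different kind on this carbon, such as an amine or a carboxylic acid, would move the number. They also do not show whether a longer alkyl chain there would match methyl and phenyl.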